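The compounds below may be only part of what the source reports. "The series", "measured", "known", "first", "only" and "open" are said of these compounds alone.

Measured so far in a functional assay on MCF cells (Homo sapiens) for antiproliferative activity, with a stated time of 72 h; on this read-out lower numbers stand for stronger inhibition and higher numbers for weaker inhibition:
- compound 1 `OC[C@H]1O[C@@H](n2cnc3c(NCc4ccc(Cl)cc4)ncnc32)[C@H](O)[C@@H]1O`; in this assay compound 1 reaches only the limit > 166000 nM.
- compound 2 `OC[C@H]1O[C@@H](n2cnc3c(NCc4ccccc4Br)ncnc32)[C@H](O)[C@@H]1O`; in this assay compound 2 also stops at the limit > 166000 nM.
- compound 3 `Cc1ccc(O)c(CNc2ncnc3c2ncn3[C@@H]2O[C@H](CO)[C@@H](O)[C@H]2O)c1`; in this assay compound 3 likewise stops at the limit > 166000 nM.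

Compound 1 therefore stands at the limit, and so does every other measured compound: the limit of > 166000 nM in this assay, at which 3 of the 3 values shown sit. The step to compound 4 `OC[C@H]1O[C@@H](n2cnc3c(NCc4cccc(C(F)(F)F)c4)ncnc32)[C@H](O)[C@@H]1O` changes the aryl group on the saturated chain carbon bound to a nitrogen on the aromatic ring: 3-(trifluoromethyl)phenyl in place of 4-chlorophenyl on a saturated chain carbon bound to a nitrogen on an aromatic ring. The steps measured at that same place, a step that the two limits leave unreadable from compound 1 to compound 2, a step that the two limits leave unreadable from compound 1 to compound 3 and a step that the two limits leave unreadable from compound 2 to compound 3, are all of unreadable size, so no direction can be taken from them. Compound 4 is expected to stay at the limit as well, with a step that the limit leaves unreadable from compound 1 to compound 4 expected to remain unreadable. Compound 4 is estimated at 250000 nM, in the range 120000 nM to 600000 nM.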

Compound 4, half-maximal inhibitory concentration: > 166000 nM
Compound 4 gave a limit, no number; the forecaster's own chance of this, stated with the estimate: 85%; the middle value does not contradict the limit.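

Compound 4 gives only a limit, > 166000 nM, so its steps from compound 1, compound 2 and compound 3 cannot be read. The compounds shown leave open whether any aryl group on the shared core gives a measurable value in this assay.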